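Cytotoxicity notes on a shared urea-to-amide replacement

The compounds below may be only part of what the source reports. "The series", "measured", "known", "first", "only" and "open" are said of these compounds alone.

In an ADME assay on HepG2 2.2.15 cells (Homo sapiens) for cytotoxicity (on this read-out higher numbers stand for lower toxicity in this test and lower numbers for higher toxicity in this test), compound 1 `CC(C)(C)OC(=O)Nc1ncc(C(Oc2ccc3cc(Br)ccc3c2)c2ccc(Cl)cc2)s1` gives > 50000 nM, which is a limit of the assay. Compound 2 `CCN(CC)C(=O)Nc1ncc(C(Oc2ccc3cc(Br)ccc3c2)c2ccc(Cl)cc2)s1` is reported in this assay as "not toxic" (no number reported), so compound 2 stands with no number of its own. The only fixed point in the series is the limit of compound 1, (the limit of > 50000 nM in this assay, at which 1 of the 2 values shown sits). Compound 3 `O=C(Nc1ncc(C(Oc2ccc3cc(Br)ccc3c2)c2ccc(Cl)cc2)s1)c1cc(F)c(F)cc1F` carries 2,4,5-trifluorophenyl in place of diethylamino on a carbonyl carbon. Among the compounds with values here, no measured step is at hand, so for compound 3 the expected change in this assay is none beyond the usual scatter, with no direction favoured. Compound 3 is expected to sit near 50000 nM, within 15000 nM to 100000 nM, most likely again as a limit.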

Compound 3, half-maximal cytotoxic concentration: "not toxic" (no number reported)
Compound 3: no number reported, and the estimate cannot be compared.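

No step can be read between compound 2 and compound 3: each stands in this assay as "not toxic", without a number. The compounds shown leave open at what concentration, if any, cytotoxicity appears.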